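Sulfonyl aryl exchange on two related quinoline-type cores

The compounds below may be only part of what the source reports. "The series", "measured", "known", "first", "only" and "open" are said of these compounds alone.

Measured so far:
compound 1 `CC1CCN(c2c(S(=O)(=O)c3cccc(F)c3)cnc3ccc(F)cc23)CC1`, 76%
compound 2 `CC1CCN(c2c(S(=O)(=O)c3ccc(C#N)cc3)cnc3ccc(F)cc23)CC1`, 75%
compound 3 `CC1CCN(c2c(S(=O)(=O)c3cccc(F)c3)cnc3c(F)cccc23)CC1`, 62%

All three numbers come from an assay on isolated protein for displacement of a labelled ligand from metabotropic glutamate receptor 5 (Homo sapiens), with a stated time of 60 min, tested at 1 uM; on this read-out lower numbers stand for less inhibition and higher numbers for more inhibition at the one concentration tested (going by the name of the read-out). Compound 1 and compound 2 differ in one place: 4-cyanophenyl in place of 3-fluorophenyl on a sulfonyl sulfur. The step is a number 1 percentage points lower from compound 1 to compound 2 (within the scatter), so the two values cannot be told apart on this read-out. Compound 3 is built from the same atoms as compound 1, joined differently; the difference between the two cores is not broken down here. In this assay compound 3 gives 62%, the lowest of the three numbers, with compound 2 and compound 1 both beyond the scatter above it.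

Compound 4 `CC1CCN(c2c(S(=O)(=O)c3ccc(C#N)cc3)cnc3c(F)cccc23)CC1` has not yet been measured. It stands to compound 3 as compound 2 stands to compound 1: 4-cyanophenyl in place of 3-fluorophenyl on a sulfonyl sulfur. The place line is the same word for word in both pairs, so this is the same change, made now on the core of compound 3. Among the compounds with values here, the only measured instance of it, the step from compound 1 to compound 2, is within the scatter, and nothing among the three compounds suggests the core of compound 3 should respond differently. Within the data shown here, the expectation is therefore a step of about a number 1 percentage points lower from compound 3 to compound 4 (within the scatter) in this assay, essentially flat, resting on the single precedent a number 1 percentage points lower from compound 1 to compound 2 (within the scatter). Compound 4 is estimated to give 61% in this assay, with a likely range from 50% to 72%.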

Compound 4, a percentage reported as inhibition, at one concentration (the size of the read-out at that concentration, not a potency): 86%
Beside the measured number, compound 4's estimate is 25 percentage points below it; measured number outside the range, above it.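

On the core of compound 3, replacing 3-fluorophenyl with 4-cyanophenyl on a sulfonyl sulfur gives a number 24 percentage points higher from compound 3 to compound 4 (beyond the scatter) in this assay. This change therefore does not carry over with the same size between the two cores, and the step measured on one core cannot be taken as a guide to the step on the other: the same change on two cores in this assay, a number 1 percentage points lower (within the scatter) from compound 1 to compound 2 and a number 24 percentage points higher (beyond the scatter) from compound 3 to compound 4, 25 percentage points apart, beyond the scatter of two such steps The comparison rests on a single pair on each core, read at one concentration, and it does not show why the cores differ, whether the gap would persist in a full measure of potency, or whether it extends to any other aryl group on the sulfonyl sulfur.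

The compounds shown leave open whether a methoxy group or a carboxylic acid on the sulfonyl aryl ring, in place of the nitrile, would also give steps that depend on the core. Also open, going by these compounds, is whether a chlorine in place of the fluorine on either core would keep the same difference between the two steps, or whether the difference is confined to the two cores seen here.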